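The source may hold more compounds than are shown below. What is called first, only, known or untested is meant among the compounds shown, and "the series" means these compounds.

Measured so far: compound 1 `N#Cc1cccc(C#Cc2cccc(C#N)n2)c1` gives 8.2 nM in an assay on membranes from brain (strain Sprague-Dawley) for displacement of a labelled ligand from metabotropic glutamate receptor 5 (Rattus norvegicus), read by scintillation counting, with a stated time of 60 min; on this read-out lower numbers stand for stronger inhibition and higher numbers for weaker inhibition; compound 2 `CC(=O)c1cccc(C#Cc2cc(F)cc(C#N)c2)n1` gives 64 nM; compound 3 `CC(=O)c1cccc(C#Cc2cccc(C#N)c2)n1` gives 114 nM.

Compound 3 has the highest number of the three, close to compound 2 and well apart from compound 1. Compound 4 `CCc1cccc(C#Cc2cccc(C#N)c2)n1` differs from compound 3 by ethyl in place of acetyl on an aromatic carbon. Among the measured compounds shown here, the only step bearing on this position is a 14-fold higher number from compound 1 to compound 3 (1.14 log units; beyond the scatter), which shows that the group on this carbon matters a great deal; the change a 1.8-fold higher number from compound 2 to compound 3 (0.25 log units; within the scatter) lies elsewhere. For the measured compounds named here, no measured step shows ethyl in place of acetyl, so the direction is uncertain, but a moderate move is expected: a 2.9-fold lower number from compound 3 to compound 4 (0.45 log units; beyond the scatter). Compound 4 is therefore estimated at 40 nM, with a range of 8 nM to 200 nM.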

Compound 4, inhibition constant: 3.4 nM
Beside the measured number, compound 4's estimate is 12-fold (1.07 log units) above it; the whole stated range lies above it.
By their numbers in this assay, from the lowest: compound 4; then compound 1; then compounds 2 and 3 (each within the scatter of the next).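

Ethyl in place of acetyl gives a 34-fold lower number from compound 3 to compound 4 (1.53 log units; beyond the scatter), so this position next to the ring nitrogen can move the number far in the favourable direction, not only the unfavourable one. Ethyl in place of cyano gives a 2.4-fold lower number from compound 1 to compound 4 (0.38 log units; beyond the scatter), which puts ethyl ahead of both other groups seen on this carbon and shows that a low number here needs no hydrogen-bond acceptor in the group. Nothing available explains why ethyl does so much better than acetyl.

As far as these compounds go, whether methyl, a longer chain such as propyl, or an amine on this carbon would give a lower or a higher number stays open. So does whether fluoro, as carried by compound 2, would shift the number of compound 4.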